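A few compounds are considered here, and "the series" means these few. Any claim that something is new, unique, unknown or untested is made for them only; others in the source may bear on it.

Compound 1 `O=S(=O)(c1cc(Cl)cc(Cl)c1)c1cnc2cc(F)ccc2c1-c1ccccc1F`, compound 2 `N#Cc1cccc(S(=O)(=O)c2cnc3c(F)cccc3c2-c2cccc(F)c2)c1` and compound 3 `O=S(=O)(c1cc(Cl)cc(Cl)c1)c1cnc2cc(F)ccc2c1-c1cccc(F)c1` have been measured in an ADME assay on microsomes from liver (Homo sapiens) for metabolic stability, tested at 2.5 uM; on this read-out lower numbers stand for slow clearance and higher numbers for fast clearance. In this assay compound 1 gives 0.93 mL/min. Compound 2 gives 0.34 mL/min. Compound 3 gives 0.41 mL/min; its value and that of compound 2 lie within the usual scatter of each other.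

Compound 1 and compound 3 share one core and differ only by 2-fluorophenyl in place of 3-fluorophenyl on an aromatic carbon. This change made a 2.3-fold higher number from compound 3 to compound 1 (0.36 log units; beyond the scatter). Compound 2 carries a different core; the difference between the two cores is not broken down here.

Compound 4 `N#Cc1cccc(S(=O)(=O)c2cnc3c(F)cccc3c2-c2ccccc2F)c1` awaits measurement. It differs from compound 2 by 2-fluorophenyl in place of 3-fluorophenyl on an aromatic carbon, the same change, at a place described in the same words. Compound 4 is expected to sit higher than compound 2 by roughly a 2.2-fold higher number from compound 2 to compound 4 (0.34 log units; beyond the scatter) because the same change earlier made a 2.3-fold higher number from compound 3 to compound 1 (0.36 log units; beyond the scatter), although the core is another one. Compound 4 is therefore estimated at about 0.75 mL/min, likely between 0.4 mL/min and 1.4 mL/min.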

Compound 4, intrinsic clearance in a liver preparation (reported as CLH), per the amount of preparation that the assay uses: 0.66 mL/min
Beside the measured number, compound 4's estimate is 1.1-fold (0.06 log units) above it; low and high end bracket the measured number.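

In this assay, 2-fluorophenyl in place of 3-fluorophenyl on an aromatic carbon gave a 1.9-fold higher number from compound 2 to compound 4 (0.29 log units; within the scatter). Set beside the earlier step, the change carried over to the second core at much the same size: the same change on two cores in this assay, a 2.3-fold higher number (0.36 log units; beyond the scatter) from compound 3 to compound 1 and a 1.9-fold higher number (0.29 log units; within the scatter) from compound 2 to compound 4, 1.2-fold (0.07 log units) apart, within the scatter of two such steps. This shows agreement on two cores only; it does not show that the step would keep its size on any further core, and it gives no reason for the step.

The compounds shown leave open how the number would respond if a chlorine, a methoxy group or an amine stood in place of the fluorine on the phenyl ring. They also leave open whether any such replacement would carry from one core to the other as this change did.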